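The source may hold more compounds than are shown below. What is called first, only, known or untested is meant among the compounds shown, and "the series" means these compounds.

Measured compounds:
Compound 1, `O=C(CCN1CCN(c2ccc(C(F)(F)F)cc2)CC1)c1ccc(F)c(Br)c1`: in an ADME assay on Vero cells (Chlorocebus sabaeus) for cytotoxicity, read by resazurin assay, with a stated time of 72 h (on this read-out higher numbers stand for weaker inhibition and lower numbers for stronger inhibition), compound 1 gives 66800 nM.
Compound 2, `O=C(CCN1CCN(c2ccc(Cl)cc2)CC1)c1ccc(F)c(Br)c1`: in this assay compound 2 gives 206000 nM.
Compound 3, `O=C(CCN1CCN(c2ccc(C(F)(F)F)cc2)CC1)c1ccc(F)c(Cl)c1`: in this assay compound 3 gives 74500 nM.

The three measured compounds share one scaffold and differ in two places. Compound 3 differs from compound 1 by chloro in place of bromo on an aromatic carbon, and this pair gives a 1.1-fold higher number from compound 1 to compound 3 (0.05 log units; within the scatter), so the two cores behave alike in this assay. Compound 2 differs from compound 1 by chloro in place of trifluoromethyl on an aromatic carbon, a change that gives a 3.1-fold higher number from compound 1 to compound 2 (0.49 log units; beyond the scatter).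

Compound 4, `O=C(CCN1CCN(c2ccc(Cl)cc2)CC1)c1ccc(F)c(Cl)c1`, has not yet been measured. It differs from compound 3 by chloro in place of trifluoromethyl on an aromatic carbon. Among the measured compounds shown here, this is the same change as the one from compound 1 to compound 2, made at the same place on the shared ring; among the four compounds it occurs twice in all.

As the core of compound 3 and the core of compound 1 stand so close in this assay, with a 1.1-fold higher number from compound 1 to compound 3 (0.05 log units; within the scatter), the second occurrence of the change is expected to behave like the first, where compound 1 to compound 2 showed a 3.1-fold higher number from compound 1 to compound 2 (0.49 log units; beyond the scatter). For compound 4 an expected step of a 3.0-fold higher number from compound 3 to compound 4 (0.47 log units; beyond the scatter) follows. Compound 4 is therefore estimated at 220000 nM, most likely between 110000 nM and 450000 nM.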

Compound 4, half-maximal inhibitory concentration: 114000 nM
Estimate against measurement, compound 4: 1.9-fold (0.29 log units) above, within the range that was stated.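

In this assay, chloro in place of trifluoromethyl on an aromatic carbon gives a 1.5-fold higher number from compound 3 to compound 4 (0.18 log units; within the scatter), and this step agrees with the earlier occurrence of the same change: the same change on two cores in this assay, a 3.1-fold higher number (0.49 log units; beyond the scatter) from compound 1 to compound 2 and a 1.5-fold higher number (0.18 log units; within the scatter) from compound 3 to compound 4, 2.0-fold (0.30 log units) apart, within the scatter of two such steps. Chloro in place of bromo on an aromatic carbon gives a 1.8-fold lower number from compound 2 to compound 4 (0.26 log units; within the scatter), and this step likewise agrees with its earlier occurrence: the same change on two cores in this assay, a 1.1-fold higher number (0.05 log units; within the scatter) from compound 1 to compound 3 and a 1.8-fold lower number (0.26 log units; within the scatter) from compound 2 to compound 4, 2.0-fold (0.30 log units) apart, within the scatter of two such steps. Within these four compounds, each change can therefore be carried from one core to the other without a difference that can be told from the scatter, but each comparison rests on a single pair of steps, and the trifluoromethyl change stands beyond the scatter on one core and within it on the other, so neither a fixed size for the change nor a real step on the second core is shown.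

The compounds shown leave open whether the agreement would hold for other groups at the place of chloro and trifluoromethyl, such as a methoxy group or a nitrile, or at the place of bromo and chloro, such as an amine. They also leave open whether it would survive a longer chain between the carbonyl and the rest of the molecule.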